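Swapping piperazine for morpholine on a shared amide core

This account rests on a few compounds, and the source may have more. Where it says the series, first, only, none or still open, it means among the compounds named here.

Of the compounds shown here, three with one shared core have been measured in a functional assay on the whole organism (strain Wistar) for inhibition, with Rattus norvegicus as the target, read by paw edema, with stated times of 60 min and 2 h, at a dose of 100 mg/kg by the oral route; a lower number here means less inhibition, a higher number more inhibition at the dose given (going by the name of the read-out). Compound 1 `COc1cc2c(cc1OC)C(CC(=O)NC(C)C)CC2` gives 37%. Compound 2 `COc1cc2c(cc1OC)C(CC(=O)NC(C)(C)C)CC2` gives 32%. Compound 3 `COc1cc2c(cc1OC)C(CC(=O)N1CCNCC1)CC2` gives 44%, the highest of the three numbers, though its gap to compound 1 lies within the scatter, a number 7 percentage points higher from compound 1 to compound 3 (within the scatter), and only its gap to compound 2 lies beyond it, a number 12 percentage points higher from compound 2 to compound 3 (beyond the scatter). The remaining step, a number 5 percentage points lower from compound 1 to compound 2 (within the scatter), stays within the scatter.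

Compound 4 `COc1cc2c(cc1OC)C(CC(=O)N1CCOCC1)CC2` has not yet been measured. It differs from compound 3 in one place: morpholin-4-yl in place of piperazin-1-yl on a carbonyl carbon. For the measured compounds named here, both measured steps into compound 3 replaced an open-chain amine with the piperazine ring; no measured step exchanged one six-membered ring for another, so nothing here shows directly how this swap will read. Going by the values given here, the only guidance is that all three measured values sit in a narrow band, from compound 2 at 32% to compound 3 at 44%. A fourth member of the series is thus expected to stay near that band.

Compound 4 is therefore estimated to give 38%, with a range from 26% to 50%. The expected step is a number 6 percentage points lower from compound 3 to compound 4 (within the scatter), which would stay within the scatter.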

Compound 4, a percentage reported as inhibition, in the whole organism at one dose (the size of the read-out at that dose, not a potency): 14%
Compound 4: the middle estimate sits 24 percentage points above what was measured; measured number below the stated range.
By their numbers in this assay, from the lowest: compound 4; then compounds 2, 1 and 3 (each within the scatter of the next, the first and the last beyond it).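

In this assay, the group on the carbonyl carbon matters more than the first three compounds suggested: two six-membered non-aromatic rings with the same heavy-atom count and two hetero atoms each are not interchangeable, giving a number 30 percentage points lower from compound 3 to compound 4 (beyond the scatter). Morpholin-4-yl also falls short of both open-chain groups, with a number 23 percentage points lower from compound 1 to compound 4 (beyond the scatter) against isopropylamino and a number 18 percentage points lower from compound 2 to compound 4 (beyond the scatter) against (tert-butyl)amino, so having a ring in this place does not by itself keep the number high. Piperazin-1-yl and morpholin-4-yl differ by one nitrogen against one oxygen and by a hydrogen-bond donor that only piperazin-1-yl carries, but no available evidence connects either difference to the drop.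

Whether that donor or the ring atom itself accounts for the gap remains open. A 4-methylpiperazin-1-yl group, which keeps both ring nitrogens but carries a methyl in place of the hydrogen, and a piperidin-1-yl group, which has a carbon in place of the second hetero atom, would help to separate these two possibilities.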